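Swapping a Sulfamoylphenyl for a Furan on the Shared Core

The source may report more compounds than this note shows. Statements on the series, on what has been measured and on what is new or still open speak of the compounds shown alone.

Three compounds share one core and differ only in a single aromatic group attached to it. Compound 1 `O=C(O)Cc1sc(C(c2ccc(F)cc2)c2ccc(F)cc2)nc1-c1cc(F)cc(F)c1` carries a 3,5-difluorophenyl there and gives 35 nM in an in vitro assay on HEK385-7 cells for displacement of a labelled ligand from prostaglandin D2 receptor 2 (Homo sapiens); a higher number here means a weaker inhibitor, a lower number a stronger inhibitor. Compound 2 `N#Cc1ccc(-c2nc(C(c3ccc(F)cc3)c3ccc(F)cc3)sc2CC(=O)O)cc1` carries a 4-cyanophenyl and gives 150 nM in this assay, while compound 3 `NS(=O)(=O)c1cccc(-c2nc(C(c3ccc(F)cc3)c3ccc(F)cc3)sc2CC(=O)O)c1` carries a 3-sulfamoylphenyl and gives 140 nM in this assay. Among these three numbers compound 3 holds the second highest: it sits close to compound 2, since a 1.1-fold lower number from compound 2 to compound 3 (0.03 log units; within the scatter), and clearly apart from compound 1, since a 4.0-fold higher number from compound 1 to compound 3 (0.60 log units; beyond the scatter).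

Compound 4 `O=C(O)Cc1sc(C(c2ccc(F)cc2)c2ccc(F)cc2)nc1-c1ccoc1` alters the same position once more: furan-3-yl in place of 3-sulfamoylphenyl on an aromatic carbon. Among the measured compounds shown here, no measured step repeats this exchange. For the measured compounds named here, the steps that bear on it are a 4.3-fold higher number from compound 1 to compound 2 (0.63 log units; beyond the scatter) and a 4.0-fold higher number from compound 1 to compound 3 (0.60 log units; beyond the scatter), which show that swapping the 3,5-difluorophenyl for either of two other six-membered rings gave a similar loss, while a 1.1-fold lower number from compound 2 to compound 3 (0.03 log units; within the scatter) shows that those two replacements hardly differ from one another. A five-membered ring has not been tried, so the direction of a 1.2-fold lower number from compound 3 to compound 4 (0.07 log units; within the scatter) is uncertain and only a small step either way is expected. Compound 4 is therefore estimated at 120 nM in this assay, with a range from 40 nM to 400 nM.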

Compound 4, half-maximal inhibitory concentration: 14 nM
Compound 4: the middle estimate sits 8.6-fold (0.93 log units) above what was measured; the whole stated range lies above it.
By their numbers in this assay, from the lowest: compound 4; then compound 1; then compounds 3 and 2 (each within the scatter of the next).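

Moving from a six-membered to a five-membered aromatic ring on this carbon, next to the ring nitrogen, produced by far the largest shifts seen at this position in this assay, with a 10-fold lower number from compound 3 to compound 4 (1.00 log units; beyond the scatter) and an 11-fold lower number from compound 2 to compound 4 (1.03 log units; beyond the scatter). The earlier compounds shown here had suggested a narrow spread, yet this position can evidently move the number much further, and in the better direction. Furan-3-yl also improves on the best of the phenyl groups, with a 2.5-fold lower number from compound 1 to compound 4 (0.40 log units; beyond the scatter), so among these four compounds the 3,5-difluorophenyl is not the best group, and the smallest group, the only one with a five-membered ring, gives the lowest number. Nothing shown here gives a cause for this gain.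

Still open, from the compounds shown here alone, is whether the gain belongs to five-membered aromatic rings in general or to furan-3-yl alone, a question that a thiophene, a pyrazole or furan-2-yl could help to separate. Also open, going by these compounds, is whether the furan ring would keep this level with a further group on it, such as a methyl group or a chlorine atom.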